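Amide nitrogen cut back to hydrogen in the series

A few compounds are considered here, and "the series" means these few. Any claim that something is new, unique, unknown or untested is made for them only; others in the source may bear on it.

Measured so far:
- compound 1 `CCC1C(=O)N(C)c2cnc(-n3ccc4cc(C(=O)NC(C)C)ccc43)nc2N1c1ccn(C)n1`: 22000 nM
- compound 2 `CCCNC(=O)c1ccc2c(ccn2-c2ncc3c(n2)N(c2ccn(C)n2)C(CC)C(=O)N3C)c1`: "not active" (no number reported)

In a functional assay on A549 cells (Homo sapiens) for antiproliferative activity, read by CCK-8 assay, with a stated time of 72 h (a lower number here means a stronger inhibitor of growth, a higher number a weaker inhibitor of growth), compound 2 stands without a number, reported as "not active" (no number reported), while compound 1 gives 22000 nM. Compound 3 `CCC1C(=O)N(C)c2cnc(-n3ccc4cc(C(N)=O)ccc43)nc2N1c1ccn(C)n1` is still unmeasured. The structural change is hydrogen in place of propyl on an amide-type nitrogen. No measured step sizes this change, so the expectation rests on one number. A modest shift at most is expected in this assay, toward measurable but weak growth inhibition, close to compound 1 at 22000 nM. For compound 3 the expected concentration for half-maximal growth inhibition is estimated at 25000 nM, with an expected range of 8000 nM to 80000 nM.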

Compound 3, concentration for 50% growth inhibition: 39500 nM
Compound 3: the middle estimate sits 1.6-fold (0.20 log units) below what was measured; measured number inside the range.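

In this assay, hydrogen and isopropyl on the amide-type nitrogen cannot be told apart, with a 1.8-fold higher number from compound 1 to compound 3 (0.25 log units; within the scatter), so at this position the isopropyl group is not needed for the weak growth inhibition seen. Compound 3, with hydrogen, gives a number, whereas compound 2, with propyl, is reported only as not active, so that step cannot be read. Nothing available bears on the reason for this pattern.

Still open, from the compounds shown here alone, is whether a methyl group or a chain ending in an amine on this nitrogen would give a number clearly apart from these.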